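Dropping the Methyl from the Thiadiazole of Compound 2

This account rests on a few compounds, and the source may have more. Where it says the series, first, only, none or still open, it means among the compounds named here.

Compound 2 `Cc1nnc(Sc2cc(NC(=O)c3ccc(Cl)cc3)c3ccccc3c2O)s1` gives 49500 nM in a functional assay on PC-3 cells (Homo sapiens) for antiproliferative activity, read by MTT assay, with a stated time of 48 h; a higher number here means a weaker inhibitor, a lower number a stronger inhibitor. The only other number shown, from compound 1 `O=C(Nc1cc(Sc2ncn[nH]2)c(O)c2ccccc12)c1ccc([N+](=O)[O-])cc1`, is 53500 nM and lies within the scatter of it. Compound 3 `COc1ccc(C(=O)Nc2cc(Sc3ncn[nH]3)c(O)c3ccccc23)cc1` reaches only the limit of this assay, > 100000 nM. Compound 4 `O=C(Nc1cc(Sc2nncs2)c(O)c2ccccc12)c1ccc(Cl)cc1` differs from compound 2 by hydrogen in place of methyl on an aromatic carbon. Among the measured compounds shown here, the one measured step, an at least 1.8-fold higher number from compound 1 to compound 3 (0.27 log units; that floor lies within the scatter), changes the amide substituent rather than this ring and runs into the limit (the limit of > 100000 nM in this assay, at which 1 of the 3 values shown sits), so it offers no guide to the methyl. With nothing bearing on the change, she expects no shift beyond the scatter, a 1.0-fold higher number from compound 2 to compound 4 (0.00 log units; within the scatter). Compound 4 is therefore estimated at 50000 nM, between 20000 nM and 100000 nM.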

Compound 4, half-maximal inhibitory concentration: > 100000 nM
Compound 4 ended at the assay's limit; the forecaster's own chance of this, stated with the estimate: 30%; middle value at least 2.0-fold (0.30 log units) from the limit.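

In this assay, among the compounds shown here, going from 5-methyl-1,3,4-thiadiazol-2-yl to 1,3,4-thiadiazol-2-yl gives an at least 2.0-fold higher number from compound 2 to compound 4 (0.30 log units; that floor lies within the scatter), the first step that touches this ring carbon. The floor of that step shows no gain from losing the methyl, though it does not establish a loss beyond the scatter. The value of compound 4 is a limit, and the full size of the step cannot be read: the limit of > 100000 nM in this assay, at which 2 of the 4 values shown sit.

From the compounds shown here alone, whether an ethyl chain or an amine on this carbon would keep the number of compound 2 stays open. Also open, going by these compounds, is whether the methyl would count the same with the nitro or methoxy amide substituents of compound 1 and compound 3.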